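The source may report more compounds than this note shows. Statements on the series, on what has been measured and on what is new or still open speak of the compounds shown alone.

Compound 1 `CCNC(=O)[C@H]1O[C@@H](n2cnc3c(NNC(=O)c4ccccc4)ncnc32)[C@H](O)[C@@H]1O`: > 5000 nM
Compound 2 `CCNC(=O)[C@H]1O[C@@H](n2cnc3c(NNC(=O)c4cccs4)nc(Cl)nc32)[C@H](O)[C@@H]1O`: 200 nM

In a functional assay on CHO cells for activation of adenosine receptor A2b (Homo sapiens), read by cAMP accumulation (on this read-out lower numbers stand for an effect already at smaller amounts and higher numbers for an effect only at larger amounts of compound), compound 1 reaches only a limit, > 5000 nM, and no number (the limit of > 5000 nM in this assay, at which 1 of the 2 values shown sits). In this assay, among the measured compounds shown here, compound 2 gives 200 nM, the only number so far, so it stands alone without a measured step to compare against. Compound 3 `CCNC(=O)[C@H]1O[C@@H](n2cnc3c(NNC(=O)c4cc(-c5ccccc5)on4)nc(Cl)nc32)[C@H](O)[C@@H]1O` differs from compound 2 in one place: 5-phenyl-1,2-oxazol-3-yl in place of thiophen-2-yl on a carbonyl carbon. For the measured compounds named here, no measured pair shows what such an exchange does here. The expected step is small, a 1.5-fold higher number from compound 2 to compound 3 (0.18 log units; within the scatter), leaning slightly toward larger amounts. Compound 3 is therefore estimated at about 300 nM, within 60 nM to 1500 nM.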

Compound 3, half-maximal effective concentration: > 5000 nM
Compound 3: no number, only a limit (the forecaster's own chance of this, stated with the estimate: 10%); at least 16-fold (1.22 log units) between middle value and limit.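

In this assay, the group on the carbonyl carbon can decide the result: 5-phenyl-1,2-oxazol-3-yl in place of thiophen-2-yl gives an at least 25-fold higher number from compound 2 to compound 3 (1.39 log units; beyond the scatter). Compound 3 gives > 5000 nM, which is a limit of the assay and not a number. This limit now recurs among the compounds: the limit of > 5000 nM in this assay, at which 2 of the 3 values shown sit.

On these data alone, it remains open whether the phenyl ring or the 1,2-oxazole ring accounts for this step. A plain 1,2-oxazol-3-yl without the phenyl ring, or a small methyl group, on that carbonyl carbon could help separate the two.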